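This account rests on a few compounds, and the source may have more. Where it says the series, first, only, none or still open, it means among the compounds named here.

Compound 1 `CC1(/C=C/c2cccc(O)c2)C=CC(=O)O1` and compound 3 `COc1cccc(/C=C/C2(C)C=CC(=O)O2)c1` share one core. In a functional assay on NCI/ADR-RES cells (Homo sapiens) for inhibition, read by sulforhodamine B assay, with a stated time of 48 h (a higher number here means a weaker inhibitor of growth, a lower number a stronger inhibitor of growth), compound 1 gives 647000 nM, while compound 3 gives 48600 nM. The change between them, (methyl in place of hydrogen on an oxygen on an aromatic ring), made a 13-fold lower number from compound 1 to compound 3 (1.12 log units; beyond the scatter). Compound 2 `CC1(/C=C/c2ccc(O)cc2)C=CC(=O)O1` has the same atoms as compound 1, joined differently; the difference between the two cores is not broken down here. In this assay compound 2 gives 111000 nM. Compound 4 `COc1ccc(/C=C/C2(C)C=CC(=O)O2)cc1` has not yet been measured in this assay. It differs from compound 2 by methyl in place of hydrogen on an oxygen on an aromatic ring, the same change as from compound 1 to compound 3, at a place described in the same words. Within the data shown here, that earlier step, a 13-fold lower number from compound 1 to compound 3 (1.12 log units; beyond the scatter), is the only guide, so the expected step is taken as similar but less certain. A step of a 9.3-fold lower number from compound 2 to compound 4 (0.97 log units; beyond the scatter) is therefore expected for compound 4. Compound 4 is expected to give about 12000 nM, likely between 3500 nM and 45000 nM.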

Compound 4, concentration for total growth inhibition: > 1000000 nM
Compound 4 was reported as a limit (the forecaster's own chance of this, stated with the estimate: 5%); middle value at least 83-fold (1.92 log units) from the limit.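

In this assay compound 4 is reported only as a limit, > 1000000 nM. Going from hydroxy to methoxy gave an at least 9.0-fold higher number from compound 2 to compound 4 (0.95 log units; beyond the scatter), so on these two cores the same change moved the number in opposite directions, and it did not carry over from one core to the other: the same change on two cores in this assay, a 13-fold lower number (1.12 log units; beyond the scatter) from compound 1 to compound 3 and an at least 9.0-fold higher number (0.95 log units; beyond the scatter) from compound 2 to compound 4, at least 110-fold (2.07 log units) apart, beyond the scatter of two such steps. This does not show why the two cores differ, and the true size of the second step stays unknown, as only a limit is available for compound 4.

From the compounds shown here alone, it remains open how either core would respond to a longer chain on that oxygen, such as ethoxy. An amine in place of the hydroxy group is equally untested among the compounds shown.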